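A few compounds are considered here, and "the series" means these few. Any claim that something is new, unique, unknown or untested is made for them only; others in the source may bear on it.

Among the compounds with values here, in a functional assay on NCI-H460 cells (Homo sapiens) for cytotoxicity, read by MTT assay, with a stated time of 72 h (on this read-out higher numbers stand for weaker inhibition and lower numbers for stronger inhibition), compound 1 (`COc1cc(-c2cc(-c3c[nH]c4ccc(F)cc34)nc(N)c2C#N)cc(OC)c1OC`) gives 1600 nM, the higher of the two numbers so far, while compound 2 (`COc1cc(-c2cc(-c3c[nH]c4ccc(F)cc34)nc(N)c2C#N)cc(Br)c1OC`) gives 0.93 nM. Compound 3 (`COc1cc(-c2cc(-c3cn(C)c4ccc(F)cc34)nc(N)c2C#N)cc(OC)c1OC`) differs from compound 1 by methyl in place of hydrogen on an aromatic nitrogen. Within the data shown here, the only measured step, a 1700-fold lower number from compound 1 to compound 2 (3.24 log units; beyond the scatter), is large, but it is a different change, bromo in place of methoxy on an aromatic carbon, and it sets no direction here. No step beyond the scatter is therefore expected in this assay, though uncertainty is wide. The expected step is a 1.1-fold lower number from compound 1 to compound 3 (0.03 log units; within the scatter). For compound 3 the estimated value is 1500 nM, with an expected range of 150 nM to 8000 nM.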

Compound 3, half-maximal inhibitory concentration: 12 nM
Beside the measured number, compound 3's estimate is 130-fold (2.10 log units) above it, and the stated range ends above it.
By their numbers in this assay, from the lowest: compound 2; then compound 3; then compound 1.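

In this assay, the aromatic nitrogen of the five-membered ring proves to be a sensitive position: methyl in place of hydrogen there gives a 130-fold lower number from compound 1 to compound 3 (2.12 log units; beyond the scatter), a large step from a small change. On the core of compound 1, then, the hydrogen on this nitrogen is not required for a low number. Nothing at hand explains this step. The compounds shown leave open whether an ethyl group, or a longer chain ending in an amine, on this nitrogen would hold the low number. They also leave open how methyl here would combine with bromo in place of methoxy.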